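The compounds below may be only part of what the source reports. "The series", "measured", "known", "first", "only" and "open" are said of these compounds alone.

In a functional assay on A549 cells (Homo sapiens) for inhibition, read by MTT assay, with a stated time of 72 h (a higher number here means a weaker inhibitor, a lower number a stronger inhibitor), compound 1 `COc1ccccc1-n1c(-c2coc3cc(C)c(Cl)cc3c2=O)nc(-c2ccccc2)c1-c1ccccc1` gives 12500 nM and compound 2 `Cc1cc2occ(-c3nc(-c4ccccc4)c(-c4ccccc4)n3-c3ccc(Br)cc3)c(=O)c2cc1Cl` gives 25000 nM as its half-maximal inhibitory concentration. These two numbers lie within the scatter of each other, so compound 2 cannot be ranked against compound 1. Compound 3 `Cc1ccc(-n2c(-c3coc4cc(C)c(Cl)cc4c3=O)nc(-c3ccccc3)c2-c2ccccc2)cc1` keeps everything in compound 2 except one group methyl in place of bromo on an aromatic carbon in a change that reads methyl in place of bromo on an aromatic carbon, para to a large group, so 4-bromophenyl becomes 4-methylphenyl. Going by the values given here, the only measured step to go on swaps the whole group on an aromatic nitrogen, 4-bromophenyl in place of 2-methoxyphenyl. Since a 2.0-fold higher number from compound 1 to compound 2 (0.30 log units; within the scatter) stays within the scatter, no step beyond the scatter is expected in this assay here. The expected step is a 1.4-fold lower number from compound 2 to compound 3 (0.14 log units; within the scatter) and it is small. For compound 3 the estimated value is 18000 nM with an expected range from 8000 nM to 40000 nM for now.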

Compound 3, half-maximal inhibitory concentration: 12500 nM
Compound 3: the middle estimate sits 1.4-fold (0.16 log units) above what was measured; the measured number falls inside the stated range.
By their numbers in this assay, from the lowest: compounds 1, 3 and 2 (each within the scatter of the next).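

Compound 3 isolates a single swap at one place on the ring, para to a large group. In this assay, methyl in place of bromo gives a 2.0-fold lower number from compound 2 to compound 3 (0.30 log units; within the scatter) and so does not separate these two groups. Exchanging the whole group on the aromatic nitrogen, 4-methylphenyl in place of 2-methoxyphenyl, gives no change at the digits printed from compound 1 to compound 3 (within the scatter) so the three groups seen there, 2-methoxyphenyl, 4-bromophenyl and 4-methylphenyl, cannot be ranked, and no compound shown goes against this. On these data alone, it remains open whether an amine, a carboxylic acid or a longer chain such as butyl at the place of the bromo would move the number beyond the scatter. No measurement at hand explains why these three compounds give such similar numbers.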